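Swapping methoxy for bromo on the pendant phenyl of compound 3

This account rests on a few compounds, and the source may have more. Where it says the series, first, only, none or still open, it means among the compounds named here.

Of the compounds shown here, three have been tested in a functional assay on PC-12 cells (Rattus norvegicus) for cytotoxicity, read by MTT assay, with stated times of 3 h and 2 h, tested at 5 uM; on this read-out higher numbers stand for a stronger effect at the one concentration tested and lower numbers for a weaker effect. Compound 1 `O=C(CCCCC1CCSS1)NCc1cn(CCCCCOc2ccc3ccc(=O)oc3c2)nn1` gives 64.5%. Compound 2 `CCOC(=O)c1cc2ccc(OCCCCCn3cc(CNC(=O)CCCCC4CCSS4)nn3)cc2oc1=O`, carrying ethoxycarbonyl in place of hydrogen on an aromatic carbon, gives 36.4%, a change of a number 28.1 percentage points lower from compound 1 to compound 2 (beyond the scatter). Compound 3 `COc1ccc(-c2cc3ccc(OCCCCCn4cc(CNC(=O)CCCCC5CCSS5)nn4)cc3oc2=O)cc1`, carrying 4-methoxyphenyl in place of hydrogen on the same aromatic carbon, gives 41%, a change of a number 23.5 percentage points lower from compound 1 to compound 3 (beyond the scatter). Between compound 2 and compound 3 the change is a number 4.6 percentage points higher from compound 2 to compound 3 (within the scatter). Compound 3 therefore stands second of the three numbers, close to compound 2 and well apart from compound 1.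

Compound 4 `O=C(CCCCC1CCSS1)NCc1cn(CCCCCOc2ccc3cc(-c4ccc(Br)cc4)c(=O)oc3c2)nn1` differs from compound 3 by bromo in place of methoxy on an aromatic carbon. Among the compounds with values here, no measured step touches this outer ring directly; the only related comparison is that replacing ethoxycarbonyl by 4-methoxyphenyl left the number where it was, as the step of a number 4.6 percentage points higher from compound 2 to compound 3 (within the scatter) shows. Exchanging one small substituent on that outer ring for another is therefore expected to give a step of a number 1 percentage points lower from compound 3 to compound 4 (within the scatter), that is, nothing beyond the scatter. The estimate for compound 4 in this assay is 40%, with a range from 27% to 55%.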

Compound 4, a percentage reported as activity, at one concentration (the size of the read-out at that concentration, not a potency): 45.7%
Beside the measured number, compound 4's estimate is 5.7 percentage points below it; low and high end bracket the measured number.
By their numbers in this assay, from the lowest: compounds 2, 3 and 4 (each within the scatter of the next); then compound 1.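

Within the data shown here, this is the first step that changes the outer ring itself, and in this assay the exchange of 4-methoxyphenyl for 4-bromophenyl gives a difference that stays inside the usual noise (a number 4.7 percentage points higher from compound 3 to compound 4 (within the scatter)). Methoxy, with its carbon and oxygen, and bromo, a single bromine atom, therefore cannot be told apart at this place on the ring. The 4-bromophenyl group also cannot be told apart from ethoxycarbonyl on the core (a number 9.3 percentage points higher from compound 2 to compound 4 (within the scatter)), whereas the version with hydrogen on that aromatic carbon remains clearly separate (a number 18.8 percentage points lower from compound 1 to compound 4 (beyond the scatter)), and no measurement available here explains why these groups read alike or why hydrogen differs.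

An amine or a carboxylic acid at the same place on the outer ring would test whether any group there can move the number beyond the scatter, since methoxy and bromo are the only two seen so far. Each reading also comes from a single concentration, so the compounds leave open whether these similarities and this gap would persist at other concentrations.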